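Extending the bromoacetyl chain on a pyrazoline series

A few compounds are considered here, and "the series" means these few. Any claim that something is new, unique, unknown or untested is made for them only; others in the source may bear on it.

Measured compounds:
compound 1, `COc1ccc(C2=NNC(c3c(Cl)cccc3Cl)C2)cc1`, 60%
compound 2, `COc1ccc(C2CC(c3ccc(OC)c(OC)c3)=NN2C(=O)CBr)c(OC)c1`, 71%
compound 3, `COc1ccc(C2=NN(C(=O)CBr)C(c3c(Cl)cccc3Cl)C2)cc1`, 7%

The three compounds were tested in a functional assay on the whole organism (strain albino) for inhibition, with Rattus norvegicus as the target, read by paw edema, with stated times of 30 min and 3 h, at a dose of 100 mg/kg by the oral route; on this read-out higher numbers stand for more inhibition at the one dose given (going by the name of the read-out) and lower numbers for less inhibition. Compound 2 stands highest of the three; compound 1 lies next, and compound 3 lies furthest, both beyond the scatter. One step between compounds differing in a single place is known: a number 53 percentage points lower from compound 1 to compound 3 (beyond the scatter), a large fall that follows the entry of (bromomethyl)carbonyl on the ring amine nitrogen.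

The unmeasured compound 4, `COc1ccc(C2CC(c3ccc(OC)c(OC)c3)=NN2C(=O)C(C)Br)c(OC)c1`, differs from compound 2 by methyl in place of hydrogen on a saturated chain carbon bound to a bromine atom and a carbonyl carbon; the chain thus goes from bromomethyl to 1-bromoethyl. Among the compounds with values here, no measured step concerns this change. Within the data shown here, the one known step, from compound 1 to compound 3, alters the ring nitrogen, a position compound 2 already carries in acylated form, so it gives no guide to a methyl added one carbon beyond the carbonyl. Among the measured compounds shown here, with no step bearing on the change, the expected step in this assay for compound 4 is none beyond the scatter, and it is estimated that a number 5 percentage points lower from compound 2 to compound 4 (within the scatter). Compound 4 is therefore expected to show 66%, with a range from 46% to 84%.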

Compound 4, a percentage reported as inhibition, in the whole organism at one dose (the size of the read-out at that dose, not a potency): 69%
Compound 4: middle estimate off by 3 percentage points, on the low side; measured number inside the range.
By their numbers in this assay, from the lowest: compound 3; then compounds 1, 4 and 2 (each within the scatter of the next, the first and the last beyond it).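

In this assay, the step of a number 2 percentage points lower from compound 2 to compound 4 (within the scatter) stays within the scatter, so compound 2 and compound 4 cannot be told apart, and this saturated chain carbon bound to a bromine atom and a carbonyl carbon accepts methyl in place of hydrogen without a measurable cost at the one dose given. Within the data shown here, the earlier compounds could not show this: their only step, a number 53 percentage points lower from compound 1 to compound 3 (beyond the scatter) and large, concerns the entry of the (bromomethyl)carbonyl group on the ring nitrogen and says nothing about the chain beyond the carbonyl, whereas the change from bromomethyl to 1-bromoethyl now gives a first reading on that chain. Nothing measured among these compounds accounts for this result.

Among these compounds, the single step leaves open how much more this chain carbon would accept, such as a second methyl, a longer chain or a phenyl group, and whether the bromine atom itself matters, which an amine or a chlorine atom in its place would test. It also leaves open whether the same methyl would behave alike on the core of compound 3, which stands at 7% in this series.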